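Swapping the Side Chain on a Shared Core

The compounds below may be only part of what the source reports. "The series", "measured", "known", "first", "only" and "open" are said of these compounds alone.

Compounds measured so far, with their values in a functional assay on the whole organism for activation, with Mus musculus as the target; a higher number here means that more compound is needed for the effect, a lower number that less compound is needed:
Compound 1, `CCCCCNc1nc(N)c2nc(O)n(Cc3ccccc3)c2n1`: 0.3 mg/kg
Compound 2, `CCOc1nc(N)c2nc(O)n(Cc3ccccc3)c2n1`: 0.3 mg/kg
Compound 3, `CCCCSc1nc(N)c2nc(O)n(Cc3ccccc3)c2n1`: 0.3 mg/kg

The three measured compounds share one core and differ only in the group attached to one aromatic carbon of that core: pentylamino in compound 1, ethoxy in compound 2 and butylsulfanyl in compound 3. Compound 3 stands level with the other two; its nearest neighbour on the numbers is compound 1, and even its furthest, compound 2, shows no separation. Each of the measured steps confirms this: no change at the digits printed from compound 1 to compound 2 (within the scatter), no change at the digits printed from compound 1 to compound 3 (within the scatter) and no change at the digits printed from compound 2 to compound 3 (within the scatter). Whether the attached group is an amine, an ether or a thioether, and whether its chain is shorter or longer, the dose needed in this assay has not moved.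

Compound 4, `CCCOc1nc(N)c2nc(O)n(Cc3ccccc3)c2n1`, is the next member of the series. It differs from compound 3 as follows: propoxy in place of butylsulfanyl on an aromatic carbon. Every measured step at this position bears on this change, and all of them were flat, so no step beyond the scatter is expected in either direction.

Compound 4 is therefore expected to give about 0.3 mg/kg in this assay, with a likely range from 0.1 mg/kg to 1 mg/kg. The step of no change at the digits printed from compound 3 to compound 4 (within the scatter) that this estimate implies is expected to remain within the usual scatter.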

Compound 4, minimum effective dose: 0.3 mg/kg
Compound 4: middle estimate and measured number agree at the digits printed; the range from low to high includes it.
By their numbers in this assay, from the lowest: compounds 1, 2, 3 and 4 (each within the scatter of the next).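

In this assay the exchange of butylsulfanyl for propoxy, which puts an oxygen link in place of a sulfur link and shortens the chain, gives no change at the digits printed from compound 3 to compound 4 (within the scatter) and so shows that the two changes together leave the dose level. Among the compounds shown here, compound 4 also adds the only comparison here in which the oxygen link stays fixed and only the chain differs: going from ethoxy to propoxy, a single added methyl on the saturated chain, gives no change at the digits printed from compound 2 to compound 4 (within the scatter) and the dose stays level for this small extension. Set against the pentylamino group, propoxy gives no change at the digits printed from compound 1 to compound 4 (within the scatter) and the flat picture on this aromatic carbon between two ring nitrogen atoms now holds for all four compounds, with amine, ether and thioether links among them.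

Going by these compounds, what would happen with a carboxylic acid, a benzyloxy group or a much longer chain at this position stays open, and with all four compounds at one level, the limits of this flat stretch are not yet visible. No measurement shown gives a reason for this flatness.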